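A few compounds are considered here, and "the series" means these few. Any claim that something is new, unique, unknown or untested is made for them only; others in the source may bear on it.

In an assay on CHO cells for agonist activity at Alpha-2C adrenergic receptor (Homo sapiens), with a stated time of 240 min (on this read-out higher numbers stand for an effect only at larger amounts of compound and lower numbers for an effect already at smaller amounts), two compounds of a shared core have been measured. Compound 1 `C=CCc1ccccc1NCC1=NCCN1` gives 158 nM in this assay, and compound 2 `Cc1ccccc1NCC1=NCCN1` gives 21.9 nM. Within the data shown here, compound 2 therefore holds the lower of the two numbers; its only neighbour is compound 1, and the step of a 7.2-fold lower number from compound 1 to compound 2 (0.86 log units; beyond the scatter) is a modest one that lies beyond the scatter. Compound 3 `CCCc1ccccc1NCC1=NCCN1` has not yet been measured in this assay. It differs from compound 2 by ethyl in place of hydrogen on a saturated chain carbon bound to an aromatic carbon. Among the measured compounds shown here, the one measured step that bears on this change is the one from compound 1 to compound 2, where trimming the chain on that same saturated carbon lowered the number, which suggests that lengthening it again, as compound 3 does, may raise the number, though ethyl is not vinyl and the chain may be tolerated differently. A moderate rise is therefore expected, rather than a large one. Compound 3 is estimated to give 60 nM in this assay, within a range from 20 nM to 180 nM, which would mean a step of a 2.7-fold higher number from compound 2 to compound 3 (0.44 log units; beyond the scatter).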

Compound 3, half-maximal effective concentration: 115 nM
Estimate against measurement, compound 3: 1.9-fold (0.28 log units) below; low and high end bracket the measured number.
By their numbers in this assay, from the lowest: compound 2; then compounds 3 and 1 (each within the scatter of the next).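

In this assay, among these compounds, the earlier compounds showed only that the chain carrying vinyl on a saturated chain carbon bound to an aromatic carbon gave a higher number than methyl did, so the vinyl end itself might have been responsible. Ethyl in the same place, which turns methyl into propyl, gives a 5.3-fold higher number from compound 2 to compound 3 (0.72 log units; beyond the scatter), so a higher number does not require vinyl, and among these three compounds the shortest group, the methyl of compound 2, keeps the lowest number. Ethyl in place of vinyl gives a 1.4-fold lower number from compound 1 to compound 3 (0.14 log units; within the scatter), which lies within the scatter, so this assay does not separate compound 1 and compound 3, and the two ends of the chain cannot be told apart here.

A butyl chain, a branched isopropyl group or an amine at the end of the chain could show whether the number keeps climbing with length, levels off or responds to the kind of group. Nothing given here explains why the number changes at this position.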